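Dropping the bromo group from an oxime series

This account rests on a few compounds, and the source may have more. Where it says the series, first, only, none or still open, it means among the compounds named here.

Measured so far:
compound 1 `COc1ccc(C(=O)/C=C/c2ccc(Br)cc2)cc1` gives 25100 nM
compound 2 `COc1ccc(C(/C=C/c2ccc(Br)cc2)=N/O)cc1` gives 13900 nM
compound 3 `COc1ccc(C(/C=C/c2ccc(Cl)cc2Cl)=N/O)cc1` gives 11200 nM

All three were measured in a functional assay (Mus musculus, strain Balb/c) for inhibition, read by ELISA, with a stated time of 72 h; on this read-out lower numbers stand for stronger inhibition and higher numbers for weaker inhibition. Going by the values given here, compound 2 sits second highest of the three numbers; compound 3 is nearest to it and compound 1 furthest, both gaps within the scatter, so no compound can be called stronger than another here.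

Compound 4 `COc1ccc(C(/C=C/c2ccccc2)=N/O)cc1` has not been measured. Its difference from compound 2 is hydrogen in place of bromo on an aromatic carbon. Among the compounds with values here, no step between measured compounds shows what this change does on its own. Since compound 2 gives 13900 nM and compound 3 gives 11200 nM with a different halogen pattern, little movement is expected; the step of a 1.3-fold higher number from compound 2 to compound 4 (0.11 log units; within the scatter) is expected to be small, if anything toward weaker inhibition. Compound 4 is estimated at 18000 nM, within 8000 nM to 45000 nM.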

Compound 4, half-maximal inhibitory concentration: 11800 nM
Compound 4: middle estimate off by 1.5-fold (0.18 log units), on the high side, and the stated range covers the measured number.
By their numbers in this assay, from the lowest: compounds 3, 4, 2 and 1 (each within the scatter of the next, the first and the last beyond it).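

Going by these compounds alone, this is the first single change read at this position. In this assay hydrogen in place of bromo, para to a large group, gives a 1.2-fold lower number from compound 2 to compound 4 (0.07 log units; within the scatter) and so, in this one pair, the bromo group can leave without a change beyond the scatter. Nothing measured here bears on why the position responds so little. The compounds shown leave open whether an amine, a carboxylic acid or a longer chain on this carbon would move the number beyond the scatter. They also leave open whether the same swap would behave alike on the core of compound 1.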